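Compound 3 to compound 4: changing the carbonyl substituent

This account rests on a few compounds, and the source may have more. Where it says the series, first, only, none or still open, it means among the compounds named here.

In an ADME assay on Vero cells (Chlorocebus sabaeus) for cytotoxicity, read by resazurin assay, with a stated time of 72 h (a lower number here means a stronger inhibitor, a higher number a weaker inhibitor), compound 1 (`Cc1ccc(C(=O)CCN2CCN(c3ccc(F)cc3)CC2)cc1`) gives 55400 nM, compound 2 (`Cc1ccc(C(=O)CCN2CCN(c3ccc(C(F)(F)F)cc3)CC2)cc1`) gives 140000 nM and compound 3 (`Cc1ccc(C(=O)CCN2CCN(c3ccc(Cl)cc3)CC2)cc1`) gives 184000 nM. For compound 3, the nearest gap is a 1.3-fold higher number from compound 2 to compound 3 (0.12 log units; within the scatter) and the furthest is a 3.3-fold higher number from compound 1 to compound 3 (0.52 log units; beyond the scatter). Compound 4 (`O=C(CCN1CCN(c2ccc(Cl)cc2)CC1)c1ccc(F)c(Br)c1`) carries 3-bromo-4-fluorophenyl in place of 4-methylphenyl on a carbonyl carbon. Going by the values given here, no measured step touches that group, so the data give only a loose guide. The measured steps that leave the scatter are modest, namely a 2.5-fold higher number from compound 1 to compound 2 (0.40 log units; beyond the scatter) and the gap to compound 3 already given. A similarly modest move toward a lower number is expected, tentatively, as a 1.8-fold lower number from compound 3 to compound 4 (0.26 log units; within the scatter). Compound 4 is expected at 100000 nM, with an estimated range of 35000 nM to 250000 nM.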

Compound 4, half-maximal inhibitory concentration: 206000 nM
For compound 4 the middle estimate is 2.1-fold (0.31 log units) below the measured one; the range from low to high includes it.
By their numbers in this assay, from the lowest: compound 1; then compounds 2, 3 and 4 (each within the scatter of the next).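

The earlier steps shown here changed only fluoro, chloro and trifluoromethyl on an aromatic carbon, whereas this one changes the group on a carbonyl carbon and leaves that part untouched. In this assay, 3-bromo-4-fluorophenyl in place of 4-methylphenyl gives no separation from the parent (a 1.1-fold higher number from compound 3 to compound 4 (0.05 log units; within the scatter)), so this single pair shows no change at this position beyond the scatter. Nothing available explains this result.

Going by these compounds, it remains open whether an amine or a carboxylic acid on that ring would separate from these two groups. Also open, on these data alone, is whether the lower number of compound 1 would persist with 3-bromo-4-fluorophenyl on the carbonyl carbon.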